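Methyl in Place of Trifluoromethyl: What Compound 4 May Give

The compounds below may be only part of what the source reports. "The series", "measured", "known", "first", "only" and "open" are said of these compounds alone.

Measured so far:
compound 1, `CN(C(=O)NC(=O)c1ccc(Cl)cc1Cl)c1nc(C(F)(F)F)c(C(=O)N/N=C/c2ccc(C(F)(F)F)cc2)s1`, gives 3.08 ug/mL.
compound 2, `CNc1nc(C)c(C(=O)N/N=C/c2cccc(C(F)(F)F)c2)s1`, is reported only as a limit, > 100 ug/mL.
compound 3, `CNc1nc(C(F)(F)F)c(C(=O)N/N=C/c2cccc(C(F)(F)F)c2)s1`, is likewise reported only as a limit, > 100 ug/mL.

The three compounds were tested in a functional assay on BCG823 cells (Homo sapiens) for inhibition, read by MTT assay, with a stated time of 72 h; a lower number here means a stronger inhibitor, a higher number a weaker inhibitor. Compound 1 is the only one of the three with a number in this assay, where it gives 3.08 ug/mL. The value of compound 2 is a limit of the assay, > 100 ug/mL. The value of compound 3 is also a limit, > 100 ug/mL. Both sit at the limit of > 100 ug/mL in this assay, at which 2 of the 3 values shown sit.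

Compound 3 and compound 2 differ by methyl in place of trifluoromethyl on an aromatic carbon. The step that the two limits leave unreadable from compound 3 to compound 2 cannot be read, because the limit of > 100 ug/mL in this assay, at which 2 of the 3 values shown sit, hides both ends of it.

Compound 4, `Cc1nc(N(C)C(=O)NC(=O)c2ccc(Cl)cc2Cl)sc1C(=O)N/N=C/c1ccc(C(F)(F)F)cc1`, differs from compound 1 by methyl in place of trifluoromethyl on an aromatic carbon. Among the compounds with values here, this is the same kind of change as the one from compound 3 to compound 2, but not the same: in compound 1 the changed carbon lies two ring bonds from the ring atom that bears a large group, while in compound 3 it lies two ring bonds from the ring atom that bears a methylamino group (2 heavy atoms). How the core of compound 1 differs from the core of compound 3 is not broken down here.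

Within the data shown here, the only measured instance of this change gives no readable size, so the expectation for compound 4 rests on compound 1 alone, whose value of 3.08 ug/mL anchors it. The step of a 1.9-fold higher number from compound 1 to compound 4 (0.29 log units; within the scatter) is expected to stay small, since the change keeps every donor and acceptor count unchanged. Compound 4 is therefore estimated at 6 ug/mL, with a range from 1.5 ug/mL to 40 ug/mL.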

Compound 4, half-maximal inhibitory concentration: 38 ug/mL
Estimate against measurement, compound 4: 6.3-fold (0.80 log units) below; measured number inside the range.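

In this assay, methyl in place of trifluoromethyl on an aromatic carbon of the core of compound 1 gives a 12-fold higher number from compound 1 to compound 4 (1.09 log units; beyond the scatter) and is therefore a large weakening on that core, with the change beside it being no more than the swap of one group for the other. The same change from compound 3 to compound 2 cannot be read, since both of its ends are limits and not numbers: the limit of > 100 ug/mL in this assay, at which 2 of the 4 values shown sit. The series therefore gives a size for this change on one core only, and it does not show whether a step of that size carries over to the core of compound 3, or to any other core, so the result from compound 1 and compound 4 stands as a single instance and not as a rule for the series.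

The compounds shown leave open how other groups at this same aromatic carbon, such as an ethyl group or a nitrile, would stand in this assay on the core of compound 1. They also leave open whether the step seen here would hold if the large group on the ring were replaced by a simple amine.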